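Bromo to isopropyl on a fused tetrazolyl quinolone

A few compounds are considered here, and "the series" means these few. Any claim that something is new, unique, unknown or untested is made for them only; others in the source may bear on it.

Compound 1, `Cc1cc([N+](=O)[O-])c2cc(-c3nn[nH]n3)cnc2c1C`, in a functional assay on the whole organism (strain Sprague-Dawley) for inhibition, with Rattus norvegicus as the target (on this read-out higher numbers stand for an effect only at larger amounts of compound and lower numbers for an effect already at smaller amounts), gives 2.5 mg/kg. Compound 2, `COc1ccc2ncc(C(=O)O)c(O)c2c1`, in this assay reaches only a limit of the assay, > 50 mg/kg. Compound 3, `O=c1c(-c2nn[nH]n2)c[nH]c2c(Br)cccc12`, likewise reaches only a limit of the assay, > 5 mg/kg.

Of the three values shown, only compound 1 has a number; the other two are limits. Compound 3 stands at the limit of > 5 mg/kg in this assay, at which 1 of the 3 values shown sits, and compound 2 stands at the limit of > 50 mg/kg in this assay, at which 1 of the 3 values shown sits. Among the measured compounds shown here, no two measured compounds differ in a single place, so no measured step can be read from these numbers.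

Compound 4, `CC(C)c1cccc2c(=O)c(-c3nn[nH]n3)c[nH]c12`, is not yet measured. It differs from compound 3 in one place: isopropyl in place of bromo on an aromatic carbon. Nothing among the measured compounds shows what such a change does in this assay, and compound 3 itself gives only a limit, so no direction can be read from the numbers shown. The step from compound 3 to compound 4 is therefore expected to stay within the usual scatter, that is a step that the limit leaves unreadable from compound 3 to compound 4. For compound 4 the estimated value in this assay is 10 mg/kg, with a range from 3 mg/kg to 50 mg/kg.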

Compound 4, minimum effective dose: 1.25 mg/kg
Compound 4: middle estimate off by 8.0-fold (0.90 log units), on the high side; the measured number lies below the stated range.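

Isopropyl in place of bromo on an aromatic carbon gives, in this assay, an at least 4.0-fold lower number from compound 3 to compound 4 (0.60 log units; beyond the scatter). Among the compounds shown here, this is the first measured sign that the group at this place, ortho to a fused ring and meta to a fused ring, matters on the shared core, and isopropyl here gives an effect at a smaller dose than the bromo compound's limit. Compound 3 gives only a limit, so the full size of the step stays unknown: the limit of > 5 mg/kg in this assay, at which 1 of the 4 values shown sits.

From the compounds shown here alone, whether an ethyl chain or an amine at this place would do as well as isopropyl stays open. For the compounds shown here, only this one pair differs in a single place, so nothing shows whether the same change would act alike on another core.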